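The source may report more compounds than this note shows. Statements on the series, on what has been measured and on what is new or still open speak of the compounds shown alone.

Measured so far, all in an in vitro functional assay on HEK285-7 cells for antagonist activity at prostaglandin D2 receptor 2 (Homo sapiens), read by BRET and beta-arrestin recruitment; a higher number here means a larger maximal response, a lower number a smaller maximal response:

compound 1, `O=C(O)Cc1sc(C(c2ccc(F)cc2)c2ccc(F)cc2)nc1-c1ccnc(N2CCCC2)c1`, gives 80%
compound 2, `O=C(O)Cc1sc(C(c2ccccc2)c2ccc(Cl)cc2)nc1-c1ccc(Cl)cc1`, gives 80%
compound 3, `COc1ccc(C(c2ccccc2)c2nc(-c3ccc(Cl)cc3)c(CC(=O)O)s2)cc1`, gives 80%

The three compounds share one core, carrying an acid side chain, and differ in the groups attached at its two ends. In this assay compound 1 stands level with compounds 2 and 3 at the digits shown: its nearest neighbour is compound 2, with no change within the scatter, and its furthest is compound 3, again with no change within the scatter. Among the measured compounds shown here, the only step between two measured compounds that differ in a single place is no change at the digits printed from compound 2 to compound 3 (within the scatter), produced by methoxy in place of chloro on an aromatic carbon, and it stays within the scatter.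

The compound still to be measured is compound 4, `O=C(O)Cc1sc(C(c2ccc(F)cc2)c2ccc(F)cc2)nc1-c1ccncc1`. Compared with compound 1, the change is hydrogen in place of pyrrolidin-1-yl on an aromatic carbon. For the measured compounds named here, no measured pair shows a change of this kind, so nothing bears on it directly; the one step available, at a different place, moved nothing, and all three measured compounds sit at the same level. On this basis a step in this assay within the scatter is expected, with no direction. Compound 4 is therefore estimated at 78%, with a range from 62% to 92%. The step this estimate means, a number 2 percentage points lower from compound 1 to compound 4 (within the scatter), is expected to stay within the scatter.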

Compound 4, largest response reached (reported as efficacy), in percent of the reference or control that the assay uses: 80%
Compound 4: the middle estimate sits 2 percentage points below what was measured, within the range that was stated.
By their numbers in this assay, from the lowest: compounds 1, 2, 3 and 4 (each within the scatter of the next).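

Putting hydrogen in place of pyrrolidin-1-yl on an aromatic carbon next to the ring nitrogen gives, in this assay, no change at the digits printed from compound 1 to compound 4 (within the scatter), so the loss of this whole group, with its 5 heavy atoms and its five-membered non-aromatic ring, does not register in this read-out. The earlier compounds shown here showed only a swap of methoxy for chloro at a different place; this pair adds that a far larger difference, at a place on the six-membered aromatic ring with 1 nitrogen, also stays within the scatter. Nothing available explains why the maximal response holds level across this change.

From the compounds shown here alone, with all the compounds shown sitting at one level, it remains open whether any group at this place can move the maximal response at all, for example a primary amine, a carboxylic acid or a longer chain ending in an amine. Also open is whether the same holds for other measures of these compounds, since a maximal response says nothing about the concentration needed to reach it.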